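This account rests on a few compounds, and the source may have more. Where it says the series, first, only, none or still open, it means among the compounds named here.

In a functional assay on HCT-116 cells (Homo sapiens) for inhibition, read by CCK-8 assay, with a stated time of 48 h (a higher number here means a weaker inhibitor, a lower number a stronger inhibitor), compound 1 `COc1cc(-c2cc3nccc(-c4cc(OC)c(OC)c(OC)c4)n3n2)cc(OC)c1OC` gives > 10000 nM, which is a limit of the assay and not a number. Next, compound 2 `COc1cc(-c2ccnc3cc(-c4ccc(F)cc4)nn23)cc(OC)c1OC` gives 5030 nM, while compound 3 `COc1cc(-c2ccnc3cc(-c4ccc(C)c(C)c4)nn23)cc(OC)c1OC` gives 261 nM, the lowest number so far. The unmeasured compound 4 `COc1cc(-c2ccnc3cc(-c4cn(C)c5ccccc45)nn23)cc(OC)c1OC` keeps the rest of compound 3 and changes one group: 1-methyl-1H-indol-3-yl in place of 3,4-dimethylphenyl on an aromatic carbon. Going by the values given here, only one measured step bears on this change, at the same aromatic carbon: a 19-fold lower number from compound 2 to compound 3 (1.28 log units; beyond the scatter). That step was large and went to a lower number, so a further fall beyond the scatter in this assay is expected, though a single step is thin support. The expected change is a 4.4-fold lower number from compound 3 to compound 4 (0.64 log units; beyond the scatter). For compound 4 the estimate is 60 nM, with an expected range of 10 nM to 400 nM.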

Compound 4, half-maximal inhibitory concentration: 762 nM
The estimate for compound 4 lay 13-fold (1.10 log units) below the measured number, and the stated range ends below it.
By their numbers in this assay, from the lowest: compound 3; then compound 4; then compound 2. At a limit, above all of these: compound 1.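

In this assay the change to 1-methyl-1H-indol-3-yl does not continue the earlier fall at this aromatic carbon but reverses part of it (a 2.9-fold higher number from compound 3 to compound 4 (0.47 log units; beyond the scatter)). The same group still reads better than 4-fluorophenyl (a 6.6-fold lower number from compound 2 to compound 4 (0.82 log units; beyond the scatter)) and so keeps part of the gain. The number at this position therefore does not simply keep falling as the group grows, and 3,4-dimethylphenyl stays the lowest of the three.

Going by these compounds, how an amine, a carboxylic acid or a longer chain would read on this carbon remains open. Nothing measured here accounts for this order.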